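Aryl change on the chain: compound 1 to compound 3

A few compounds are considered here, and "the series" means these few. Any claim that something is new, unique, unknown or untested is made for them only; others in the source may bear on it.

Measured so far:
compound 1 `COc1ccc(C(=O)/C=C/c2ccc(N(C)C)cc2)c2c1C=CC(C)(C)O2` — 730 nM
compound 2 `COc1ccc(C(=O)/C=C/c2ccc(-n3ccnc3)cc2)c2c1C=CC(C)(C)O2` — > 10000 nM

In a functional assay on HepG2 cells (Homo sapiens) for antiproliferative activity, read by MTT assay, with a stated time of 24 h (on this read-out lower numbers stand for stronger inhibition and higher numbers for weaker inhibition), compound 1 holds the only number shown. For compound 2 the value in this assay is a limit of the assay, not a number; the limit of > 10000 nM in this assay, at which 1 of the 2 values shown sits, marks it. For the measured compounds named here, the one measured step, an at least 13-fold higher number from compound 1 to compound 2 (1.13 log units; beyond the scatter), is large. Compound 3 `COc1ccc(C(=O)/C=C/c2cccs2)c2c1C=CC(C)(C)O2` differs from compound 1 by thiophen-2-yl in place of 4-(dimethylamino)phenyl on a double-bonded chain carbon bound to a double-bonded chain carbon. The same dimethylamino leaves here, so the step to compound 2 bears on this change, and a weaker result is expected for compound 3, the expected step being a 4.8-fold higher number from compound 1 to compound 3 (0.68 log units; beyond the scatter). Compound 3 is therefore estimated at 3500 nM, within 1000 nM to 10000 nM.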

Compound 3, half-maximal inhibitory concentration: > 10000 nM
Compound 3: no number, only a limit (the forecaster's own chance of this, stated with the estimate: 35%); middle value at least 2.8-fold (0.45 log units) away from the limit.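

Putting thiophen-2-yl in place of the whole 4-(dimethylamino)phenyl gives an at least 13-fold higher number from compound 1 to compound 3 (1.13 log units; beyond the scatter). On these data alone, the value of compound 3 is a limit of the assay, not a number, so the full size of this step stays unknown. Compound 3 now joins compound 2 at the same limit, leaving compound 1, with its dimethylamino group, as the only one with a number: the limit of > 10000 nM in this assay, at which 2 of the 3 values shown sit.

Compound 2 and compound 3 cannot be ordered against each other. As far as these compounds go, whether another amine on the phenyl ring, such as diethylamino or pyrrolidin-1-yl, keeps a measurable value remains open.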